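This account rests on a few compounds, and the source may have more. Where it says the series, first, only, none or still open, it means among the compounds named here.

Measured so far in an assay on Sf9 cells for inhibition of protein deacetylase HDAC6 (Homo sapiens), read by fluorescence, with a stated time of 40 min, tested at 100 nM; a lower number here means less inhibition, a higher number more inhibition at the concentration tested (going by the name of the read-out):
compound 1 `O=C(NO)c1ccc(NCc2nc(-c3ccccc3)nn2-c2ccc(Cl)cc2)cc1` gives 55.4%
compound 2 `Cc1ccc(-n2nc(-c3ccccc3)nc2CNc2ccc(C(=O)NO)cc2)cc1C` gives 53%

Among the compounds with values here, compound 2 and compound 1 sit within the scatter of each other in this assay; the only measured step is a number 2.4 percentage points lower from compound 1 to compound 2 (within the scatter), so the two values cannot be told apart on these numbers. Compound 3 `O=C(NO)c1ccc(NCc2nc(-c3ccccc3)nn2-c2ccc(F)cc2)cc1` remains to be measured. It differs from compound 2 by 4-fluorophenyl in place of 3,4-dimethylphenyl on an aromatic nitrogen. Within the data shown here, the one step that bears on this change is the exchange of one aryl group for another on the same aromatic nitrogen, a number 2.4 percentage points lower from compound 1 to compound 2 (within the scatter), which stayed within the scatter. A further exchange of the same kind at the same aromatic nitrogen is therefore expected to give a step of no change at the digits printed from compound 2 to compound 3 (within the scatter), nothing beyond the scatter. For compound 3 the estimated value in this assay is 53%, with a range from 40% to 66%.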

Compound 3, a percentage reported as inhibition, at one concentration (the size of the read-out at that concentration, not a potency): 67.6%
For compound 3 the middle estimate is 14.6 percentage points below the measured one, outside the stated range (above it).
By their numbers in this assay, from the lowest: compounds 2 and 1 (each within the scatter of the next); then compound 3.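

In this assay the aryl group on the aromatic nitrogen is not a silent place: 4-fluorophenyl in place of 3,4-dimethylphenyl gives a number 14.6 percentage points higher from compound 2 to compound 3 (beyond the scatter). Fluoro in place of chloro on an aromatic carbon, a single-atom exchange, gives a number 12.2 percentage points higher from compound 1 to compound 3 (beyond the scatter), so the gain goes with 4-fluorophenyl specifically and not with a halogen as such, since the 4-chlorophenyl of compound 1 goes against any such pattern. No measurement on these compounds accounts for why 4-fluorophenyl stands apart.

Open, from the compounds shown here alone, is how far this reaches to other groups on that nitrogen, such as unsubstituted phenyl, 4-methoxyphenyl or 4-trifluoromethylphenyl. Also open, going by these compounds, is whether the same order would hold with another group in place of the phenyl on the ring atom that bears it, such as a pyridine ring.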